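The source may report more compounds than this note shows. Statements on the series, on what has been measured and on what is new or still open speak of the compounds shown alone.

Compound 1 `O=C(Nc1cccc(C(F)(F)F)c1)N[C@H]1CC[C@H](O)CC1` gives > 20000 nM in a functional assay on CRL2813 cells (Homo sapiens) for cytotoxicity, read by sulforhodamine B assay, with a stated time of 5 days (on this read-out lower numbers stand for stronger inhibition and higher numbers for weaker inhibition), which is a limit of the assay rather than a number.
Compound 2 `O=C(Nc1cccc(C(F)(F)F)c1)N[C@H]1CC[C@H](Oc2ccc(OC(F)(F)F)cc2)CC1` gives 690 nM in this assay.

Going by the values given here, compound 2 holds the only number given here, while the other value, (the limit of > 20000 nM in this assay, at which 1 of the 2 values shown sits), is only a limit. Compound 3 `O=C(Nc1cccc(C(F)(F)F)c1)N[C@H]1CC[C@H](Oc2ccc(Cl)cc2)CC1` differs from compound 2 by chloro in place of trifluoromethoxy on an aromatic carbon. Among the compounds with values here, no measured step of this kind is available, so the account expects the change from compound 2 to compound 3 to stay within the usual scatter, with at most a slight loss. Compound 3 is therefore estimated at 1000 nM, between 300 nM and 4000 nM, a step of a 1.4-fold higher number from compound 2 to compound 3 (0.16 log units; within the scatter).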

Compound 3, half-maximal inhibitory concentration: 2000 nM
Compound 3: the middle estimate sits 2.0-fold (0.30 log units) below what was measured; the range from low to high includes it.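

Chloro in place of trifluoromethoxy on an aromatic carbon para to a large group gives a 2.9-fold higher number from compound 2 to compound 3 (0.46 log units; beyond the scatter), so in this assay the choice of group at this position counts. The 4-chlorophenyl in place of hydrogen on the oxygen gives an at least 10-fold lower number from compound 1 to compound 3 (1.00 log units; beyond the scatter), so this gain does not depend on trifluoromethoxy alone. Compound 1 stands at a limit of the assay and not at a number, so that step has only a bound: the limit of > 20000 nM in this assay, at which 1 of the 3 values shown sits.

The compounds shown leave open how a methoxy, a nitrile or an amine on this aromatic carbon would read. They also leave open what a plain phenyl on the oxygen would give.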